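Adding Two Methyl Groups to the Pyridinyl Ether of Compound 2

The source may hold more compounds than are shown below. What is called first, only, known or untested is meant among the compounds shown, and "the series" means these compounds.

Of the compounds shown here, three sharing one core have been measured in a functional assay on CHO cells for positive allosteric modulation of metabotropic glutamate receptor 2 (Homo sapiens), read by scintillation counting and GTPgammaS binding, with a stated time of 30 min; a lower number here means a smaller maximal response, a higher number a larger maximal response. Compound 1 `COc1cccc(-c2ccn(CCC(C)C)c(=O)c2C#N)c1` gives 176%. Compound 2 `CC(C)CCn1ccc(-c2ccc(Oc3cccnc3)cc2)c(C#N)c1=O` gives 231%. Compound 3 `CC(C)CCn1ccc(-c2ccc(NC3CCOCC3)c(Cl)c2)c(C#N)c1=O` gives 247%. Compound 2 thus stands second of the three: compound 3 lies above it beyond the scatter, and compound 1 lies well below it, also beyond the scatter.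

Compound 4 `Cc1ccc(Oc2ccc(-c3ccn(CCC(C)C)c(=O)c3C#N)cc2)c(C)n1` differs from compound 2 in one place: 2,6-dimethylpyridin-3-yl in place of pyridin-3-yl on an oxygen on an aromatic ring. For the measured compounds named here, no measured pair shows this exact change, so the expectation rests on the shared core and the small size of the alteration. Compound 4 is expected to give 235%, within 195% to 275%. The estimated step of a number 4 percentage points higher from compound 2 to compound 4 (within the scatter) is expected to stay within the scatter, with no clear direction.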

Compound 4, largest response reached (Emax), in percent of the reference or control that the assay uses: 246%
For compound 4 the middle estimate is 11 percentage points below the measured one; low and high end bracket the measured number.
By their numbers in this assay, from the lowest: compound 1; then compound 2; then compounds 4 and 3 (each within the scatter of the next).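

In this assay, placing 2,6-dimethylpyridin-3-yl in place of pyridin-3-yl on the oxygen gives a step of a number 15 percentage points higher from compound 2 to compound 4 (beyond the scatter), a modest gain in maximal response. For the compounds shown here, this is the first single change that can be read at this position, as the earlier compounds offered no pair differing in one place. Nothing measured here bears on the origin of this step.

As far as these compounds go, it remains open whether a single methyl group would give a similar step. From the compounds shown here alone, the effect of a methoxy group, a chlorine or an amine on the same pyridine ring also remains open.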